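Crown-ether esters: benzyl to cyclohexyl on the pentanoate chain

This account rests on a few compounds, and the source may have more. Where it says the series, first, only, none or still open, it means among the compounds named here.

Compound 2 `O=C(CCCCCc1ccccc1)OCC1COCCOCCOCCOCCOCCO1` carries a 5-phenylpentyl chain on the carbonyl carbon, and in a functional assay on HBL-100 cells (Homo sapiens) for inhibition, read by sulforhodamine B assay, with a stated time of 48 h (on this read-out higher numbers stand for weaker inhibition of growth and lower numbers for stronger inhibition of growth), compound 2 gives 64000 nM. Compound 1 `O=C(/C=C/c1ccccc1)OCC1COCCOCCOCCOCCOCCO1` has 2-phenylethenyl in the same place, and in this assay compound 1 gives 57000 nM; the step of a 1.1-fold higher number from compound 1 to compound 2 (0.05 log units; within the scatter) is flat. Of the two numbers shown, compound 2 stands highest, with compound 1 nearest. Compound 3 `O=C(CCCCC1CCCCC1)OCC1COCCOCCOCCOCCO1` bears the cyclohexyl chain on a smaller core, and in this assay compound 3 gives only a limit, > 100000 nM, consistent with the limit of > 100000 nM in this assay, at which 1 of the 3 values shown sits.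

Compound 4 `O=C(CCCCC1CCCCC1)OCC1COCCOCCOCCOCCOCCO1` differs from compound 2 by cyclohexyl in place of benzyl on a saturated chain carbon, four bonds along the chain from a carbonyl carbon. Going by the values given here, no measured step covers this change; the single measured step, a 1.1-fold higher number from compound 1 to compound 2 (0.05 log units; within the scatter), concerns the other end of the chain and is within the scatter. Compound 3, which shares the cyclohexyl chain, reaches only a limit in this assay. The step of a 1.4-fold higher number from compound 2 to compound 4 (0.15 log units; within the scatter) is therefore expected to be small or upward, with a real chance of another limit. Compound 4 is estimated at 90000 nM, between 45000 nM and 200000 nM.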

Compound 4, concentration for 50% growth inhibition: 72000 nM
Estimate against measurement, compound 4: 1.3-fold (0.10 log units) above, within the range that was stated.
By their numbers in this assay, from the lowest: compounds 1, 2 and 4 (each within the scatter of the next). At a limit, above all of these: compound 3.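

Cyclohexyl in place of benzyl at this place, on a saturated chain carbon, four bonds along the chain from a carbonyl carbon, leaves the number in this assay flat, with a 1.1-fold higher number from compound 2 to compound 4 (0.05 log units; within the scatter), so an aromatic ring at the chain end is not needed for this level of growth inhibition. The larger change on the carbonyl carbon, 4-cyclohexylbutyl in place of 2-phenylethenyl, is also flat, with a 1.3-fold higher number from compound 1 to compound 4 (0.10 log units; within the scatter), and compounds 1, 2 and 4 cannot be ordered. Compound 3, with the same chain on a smaller core, stands at a limit: the limit of > 100000 nM in this assay, at which 1 of the 4 values shown sits.

On these data alone, how far the smaller core separates compound 3 from compound 4 stays open, as a limit is not a number. Also open, as far as these compounds go, is whether an amine or a carboxylic acid at the chain end, or a longer chain, would move the number beyond the scatter.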